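A few compounds are considered here, and "the series" means these few. Any claim that something is new, unique, unknown or untested is made for them only; others in the source may bear on it.

Three compounds in this series have been characterised in an assay on HEK293 cells for inhibition of Fatty-acid amide hydrolase 1 (Homo sapiens), read by fluorescence; a lower number here means a stronger inhibitor, a higher number a weaker inhibitor. Compound 1 `c1cnc2ccc(-c3ccc4oc(NC5CCCCC5)nc4c3)cc2c1` reaches only (the limit of > 1000 nM in this assay, at which 1 of the 3 values shown sits), so its value of > 1000 nM is a limit and not a number. Compound 2 `c1cc2c(ccn2C2COC2)cc1-c1ccc2oc(NC3CCCCC3)nc2c1` gives 579 nM in this assay. Compound 3 `CN(c1ccccc1)c1nc2cc(-c3ccc4c(ccn4C)c3)ccc2o1` gives 68 nM in this assay, the lower of the two numbers on record, and the gap from it up to compound 2 lies beyond the scatter. No pair among these three differs in a single place, so the comparison from compound 3 onward rests on the structures alone.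

Compound 4 `Cn1ccc2cc(-c3ccc4oc(N5CCCC5)nc4c3)ccc21` is not yet measured. It differs from compound 3 by pyrrolidin-1-yl in place of methyl(phenyl)amino on an aromatic carbon, with the six-membered aromatic ring of the leaving group gone and a smaller saturated ring left in its place. Nothing measured here tells how this assay answers such a swap. On that basis compound 4 is expected to sit somewhat above compound 3, with a step of a 3.7-fold higher number from compound 3 to compound 4 (0.57 log units; beyond the scatter) in this assay, and its estimated value is 250 nM, expected between 70 nM and 900 nM.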

Compound 4, half-maximal inhibitory concentration: 674 nM
Beside the measured number, compound 4's estimate is 2.7-fold (0.43 log units) below it; the measured number falls inside the stated range.
By their numbers in this assay, from the lowest: compound 3; then compounds 2 and 4 (each within the scatter of the next). At a limit, above all of these: compound 1.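

In this assay, replacing methyl(phenyl)amino with pyrrolidin-1-yl on the aromatic carbon next to the ring nitrogen and next to the ring oxygen gives a 9.9-fold higher number from compound 3 to compound 4 (1.00 log units; beyond the scatter). Within the data shown here, this is the first comparison that differs in one place, and it shows that inhibition in this assay depends on the group held at this position. The swap changes the ring type and the heavy-atom count together, and nothing measured here separates these two changes or gives a reason for the step.

The compounds shown leave open whether the phenyl ring alone accounts for the step, which a phenylamino group or a piperidin-1-yl ring at the same place could help to settle. They also leave open how a benzylamino group, with its aromatic ring set further from the core, would compare.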